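The compounds below may be only part of what the source reports. "The series", "measured", "known", "first", "only" and "open" are said of these compounds alone.

In a functional assay on V79 cells (Cricetulus griseus) for cytotoxicity, read by colony formation (a higher number here means a weaker inhibitor, a lower number a stronger inhibitor), three compounds have been measured:

Compound 1, `CC1(CN)CCN(c2c(F)cc3c(=O)c(C(=O)O)cn(C4CC4)c3c2F)C1`, gives 8 ug/mL.
Compound 2, `CC1(CN)CCN(c2c(F)cc3c(=O)c(C(=O)O)cn(C4CC4)c3c2Cl)C1`, gives 8 ug/mL.
Compound 3, `CC1CN(c2c(F)cc3c(=O)c(C(=O)O)cn(C4CC4)c3c2F)CC(C)N1`, gives 150 ug/mL.

Compound 4, `CC1CN(c2c(F)cc3c(=O)c(C(=O)O)cn(C4CC4)c3c2Cl)CC(C)N1`, has not yet been measured in this assay. It differs from compound 3 by one change: chloro in place of fluoro on an aromatic carbon. The same kind of change links two compounds that are already measured, compound 1 and compound 2: chloro in place of fluoro on an aromatic carbon. That step gave no change at the digits printed from compound 1 to compound 2 (within the scatter). The two cores on which the change is made differ themselves, and this difference is counted: 3,5-dimethylpiperazin-1-yl in place of 3-(aminomethyl)-3-methylpyrrolidin-1-yl on an aromatic carbon, a change that gave a 19-fold higher number from compound 1 to compound 3 (1.27 log units; beyond the scatter). The surroundings of the exchanged atom are therefore not identical: in compound 1 the carbon is ortho to a 3-(aminomethyl)-3-methylpyrrolidin-1-yl group, in compound 3 it is ortho to a 3,5-dimethylpiperazin-1-yl group, so the two changes are of the same kind rather than the same.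

Among the compounds with values here, with only one earlier example, compound 4 is expected to show no change at the digits printed from compound 3 to compound 4 (within the scatter), a step of about the same size as no change at the digits printed from compound 1 to compound 2 (within the scatter), because that step stayed within the scatter. Compound 4 is thus estimated at 150 ug/mL in this assay, plausibly between 60 ug/mL and 350 ug/mL.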

Compound 4, half-maximal inhibitory concentration: 140 ug/mL
For compound 4 the middle estimate is 1.1-fold (0.03 log units) above the measured one, and the stated range covers the measured number.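

In this assay, chloro in place of fluoro gave a 1.1-fold lower number from compound 3 to compound 4 (0.03 log units; within the scatter), and this change carried over from one core to the other with the same outcome: the same change on two cores in this assay, no change at the digits printed (within the scatter) from compound 1 to compound 2 and a 1.1-fold lower number (0.03 log units; within the scatter) from compound 3 to compound 4, 1.1-fold (0.03 log units) apart, within the scatter of two such steps. Putting 3,5-dimethylpiperazin-1-yl in place of 3-(aminomethyl)-3-methylpyrrolidin-1-yl gave an 18-fold higher number from compound 2 to compound 4 (1.24 log units; beyond the scatter), so the large step also held whichever of the two halogens was present: the same change on two cores in this assay, a 19-fold higher number (1.27 log units; beyond the scatter) from compound 1 to compound 3 and an 18-fold higher number (1.24 log units; beyond the scatter) from compound 2 to compound 4, 1.1-fold (0.03 log units) apart, within the scatter of two such steps. Together, these four compounds show that the two changes acted independently of each other in this assay, but they cover only two cores and one halogen exchange, so they neither predict the outcome on other cores nor explain why the numbers behave this way.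

On these data alone, it remains open whether a different group on that aromatic carbon, such as hydrogen, methyl or methoxy, would also leave the number where it is. As far as these compounds go, it is equally open how other amines in place of these two groups, such as unsubstituted piperazin-1-yl, would behave alongside fluoro or chloro.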